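The source may report more compounds than this note shows. Statements on the series, on what has been measured and on what is new or still open speak of the compounds shown alone.

Measured so far:
Compound 1, `Cc1cc2c(c(N)nn2C)c(=O)[nH]1`: 4%
Compound 2, `Cn1nc(N)c2c(=O)[nH]c(-c3ccccc3)cc21`: 9%
Compound 3, `COCCNc1nc(C)cc2c1c(N)nn2C`: 0%

All three numbers come from an assay on isolated protein for inhibition of ribosomal protein S6 kinase alpha-5 (Homo sapiens), read by mobility shift assay, tested at 30 uM; a higher number here means more inhibition at the concentration tested (going by the name of the read-out), a lower number less inhibition. Compound 1 gives 4% and compound 2 gives 9%. The two differ by phenyl in place of methyl on an aromatic carbon, and this gave a number 5 percentage points higher from compound 1 to compound 2 (within the scatter). Compound 3 gives 0% in this assay. How the core of compound 3 differs from the core of compound 1 is not broken down here.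

Compound 4, `COCCNc1nc(-c2ccccc2)cc2c1c(N)nn2C`, has not yet been measured. It differs from compound 3 by phenyl in place of methyl on an aromatic carbon. Within the data shown here, this is the same kind of change as the one from compound 1 to compound 2, though the surroundings are not identical: in compound 1 the place is meta to a group of 1 heavy atom, while in compound 3 it is meta to a (2-methoxyethyl)amino group (5 heavy atoms). Since the earlier step stayed within the scatter, the step from compound 3 to compound 4 in this assay is expected to be small, about a number 5 percentage points higher from compound 3 to compound 4 (within the scatter). Compound 4 is therefore estimated at 5%, expected to fall between -5% and 15%.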

Compound 4, a percentage reported as inhibition, at one concentration (the size of the read-out at that concentration, not a potency): 0%
Compound 4: the middle estimate sits 5 percentage points above what was measured; the range from low to high includes it.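

In this assay, putting phenyl in place of methyl on an aromatic carbon gave no change at the digits printed from compound 3 to compound 4 (within the scatter). Set beside the earlier case, the two cores give no sign of responding differently to this change: the same change on two cores in this assay, a number 5 percentage points higher (within the scatter) from compound 1 to compound 2 and no change at the digits printed (within the scatter) from compound 3 to compound 4, 5 percentage points apart, within the scatter of two such steps. This does not show that the change carries a real effect from one core to the other, as neither step stands out from the scatter and a reading at one concentration is not a potency, so the agreement may only mean that both steps are too small to tell apart.

The compounds shown leave open whether any group on this aromatic carbon can lift inhibition clear of the scatter, on either core. A carboxylic acid or an aminomethyl group at that place, or a longer chain in place of the (2-methoxyethyl)amino group, would be a further test of how this series responds to change.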